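The source may hold more compounds than are shown below. What is called first, only, known or untested is meant among the compounds shown, and "the series" means these compounds.

In a functional assay on NCI-H460 cells (Homo sapiens) for inhibition, read by sulforhodamine B assay, with a stated time of 48 h (a higher number here means a weaker inhibitor of growth, a lower number a stronger inhibitor of growth), compound 1 (`CC(C)(C)NCc1c(C(=O)O)nn(-c2ccc(Cl)cc2)c1-c1ccccc1`) gives > 652000 nM, which is a limit of the assay and not a number. Compound 2 (`Cc1ccc(-c2c(CNC(C)(C)C)c(C(=O)O)nn2-c2ccc(Cl)cc2)cc1`) gives > 629000 nM, which is also a limit. Among the compounds with values here, compound 2 thus has no exact value, and the one other value shown is a limit as well. Compound 3 (`COc1ccc(-c2c(CNC(C)(C)C)c(C(=O)O)nn2-c2ccc(Cl)cc2)cc1`) differs from compound 2 by methoxy in place of methyl on an aromatic carbon, para to a large group, or 4-methylphenyl to 4-methoxyphenyl. Within the data shown here, the one measured step that bears on this change is a step that the two limits leave unreadable from compound 1 to compound 2, with methyl in place of hydrogen on an aromatic carbon. That step offers no size to carry over, so no step beyond the scatter is expected in this assay. Compound 3 is estimated at 600000 nM, with an expected range from 300000 nM to 900000 nM. The estimate means an expected at least 1.0-fold lower number from compound 2 to compound 3 (0.02 log units; that floor lies within the scatter).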

Compound 3, concentration for 50% growth inhibition: > 605000 nM
Compound 3 ended at the assay's limit; the forecaster's own chance of this, stated with the estimate: 85%; at least 1.0-fold (0.00 log units) between middle value and limit.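

In this assay compound 3 gives > 605000 nM, which is a limit of the assay and not a number. Within the data shown here, compound 1 and compound 2 also stand at limits, so no step among the three can be read. The compounds shown leave open whether any substituent at this aromatic carbon gives a measurable growth inhibition.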